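The compounds below may be only part of what the source reports. "The series", "measured", "known", "first", "only" and "open" are said of these compounds alone.

Measured compounds:
Compound 1, `COc1ccc([C@H]2CC(=O)N(C(=O)c3ccccc3)C2)cc1OC1CCCC1`: in a functional assay on HEK293 cells (Homo sapiens) for cytotoxicity (a higher number here means that more compound is tolerated, a lower number that less compound is tolerated), compound 1 gives > 10000 nM, which is a limit of the assay and not a number.
Compound 2, `COc1ccc([C@H]2CC(=O)N(c3ccccc3C#N)C2)cc1OC1CCCC1`: compound 2 gives > 10000 nM, again only a limit.
Compound 3, `COc1ccc([C@H]2CC(=O)N(c3ccccc3C)C2)cc1OC1CCCC1`: compound 3 gives > 10000 nM, also a limit.

Among the compounds with values here, compound 3 therefore stands at the limit of > 10000 nM in this assay, at which 3 of the 3 values shown sit, where every value so far sits. The steps a step that the two limits leave unreadable from compound 1 to compound 2, a step that the two limits leave unreadable from compound 1 to compound 3 and a step that the two limits leave unreadable from compound 2 to compound 3 cannot be sized because all three values sit at the limit of > 10000 nM in this assay, at which 3 of the 3 values shown sit. Compound 4, `COc1ccc([C@H]2CC(=O)N(c3cccc(S(C)(=O)=O)c3)C2)cc1OC1CCCC1`, differs from compound 3 by 3-(methylsulfonyl)phenyl in place of 2-methylphenyl on an amide-type nitrogen in a ring. The measured steps bear on it only by showing no readable change in this assay for any swap at this nitrogen. Compound 4 is expected to give 10000 nM (range 4000 nM to 30000 nM), so the expected step is a number no higher from compound 3 to compound 4 (the limit leaves the size open), none beyond the scatter.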

Compound 4, half-maximal cytotoxic concentration: > 10000 nM
Compound 4: only a limit was reported (the forecaster's own chance of this, stated with the estimate: 80%); the middle value lies on the limit itself.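

The steps from compound 1, compound 2 and compound 3 to compound 4 cannot be read, because each compound gives only a limit, not a number: the limit of > 10000 nM in this assay, at which 4 of the 4 values shown sit.

Left open is the concentration at which any of these compounds becomes toxic in this assay, and whether the group on the nitrogen matters there at all.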